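Diaryl urea series: moving to a 5-fluoro-2-methoxyphenyl amine

The source may hold more compounds than are shown below. What is called first, only, known or untested is meant among the compounds shown, and "the series" means these compounds.

Measured so far in a functional assay on NCI-H226 cells (Homo sapiens) for inhibition, read by MTT assay, with a stated time of 48 h, tested at 10 uM; on this read-out lower numbers stand for less inhibition and higher numbers for more inhibition at the one concentration tested (going by the name of the read-out):
- compound 1, `COc1cc(NC(=O)Nc2cc(Nc3ccc(C)c(F)c3)ncn2)cc(OC)c1`: 39.7%
- compound 2, `COc1cc(Nc2cc(NC(=O)Nc3c(Cl)cccc3Cl)ncn2)cc(C(F)(F)F)c1`: 33.1%
- compound 3, `COc1ccc(Nc2cc(NC(=O)Nc3c(Cl)cccc3Cl)ncn2)cc1C`: 50%

Three compounds share the urea-linked core and have been run in this assay. Compound 1 sits second highest of the three numbers. Its nearest neighbour is compound 2, whose value lies within the usual scatter of compound 1, so the two cannot be ordered on this read-out. Compound 3 gives a higher number than compound 1, and that gap lies beyond the scatter. Among the compounds with values here, no pair among the three differs in only one place, so no single structural step can be read off from the measured set.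

Compound 4, `COc1cc(NC(=O)Nc2cc(Nc3cc(F)ccc3OC)ncn2)cc(OC)c1`, has not yet been measured. It is derived from compound 1 by one change: 5-fluoro-2-methoxyphenyl in place of 3-fluoro-4-methylphenyl on a nitrogen on an aromatic ring. Both groups are a single six-membered aromatic ring of carbon only carrying one fluorine; the entering group adds one hydrogen-bond acceptor through its methoxy. Nothing in the measured set speaks to this exchange, so no shift beyond the scatter is expected, and the step from compound 1 to compound 4 is estimated at a number 1.7 percentage points lower from compound 1 to compound 4 (within the scatter). Compound 4 is therefore expected to give about 38% in this assay, within a range of 22% to 54%.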

Compound 4, a percentage reported as inhibition, at one concentration (the size of the read-out at that concentration, not a potency): 37.7%
Estimate against measurement, compound 4: 0.3 percentage points above; measured number inside the range.
By their numbers in this assay, from the lowest: compounds 2, 4 and 1 (each within the scatter of the next); then compound 3.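

In this assay, within the data shown here, 5-fluoro-2-methoxyphenyl in place of 3-fluoro-4-methylphenyl on a nitrogen on an aromatic ring gives a number 2 percentage points lower from compound 1 to compound 4 (within the scatter), and this is the first step that can be read in one place. The read-out does not separate the two groups, so at this position, on the core of compound 1, a methoxy with its hydrogen-bond acceptor can enter and the methyl can leave, with the fluorine also sitting differently, without a change beyond the scatter. No measurement at hand offers a reason for the size of this step.

Open, as far as these compounds go, is whether a different kind of group on this nitrogen, such as a simple aliphatic amine chain or a carboxylic acid on the aromatic ring, would move the number beyond the scatter, and whether the methoxy or the fluorine of 5-fluoro-2-methoxyphenyl matters when taken alone. Also open, from the compounds shown here alone, is whether the same exchange reads the same way with another group on the urea, such as an unsubstituted phenyl.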